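Cytotoxicity series: amide variation and amine-side swap

This account rests on a few compounds, and the source may have more. Where it says the series, first, only, none or still open, it means among the compounds named here.

Measured so far:
- compound 1, `N[C@H]1CC[C@H](Nc2c(C(=O)NCc3ccco3)nc(Br)c3cccnc23)CC1`: > 10000 nM
- compound 2, `CN(C)CCCNc1c(C(=O)NCc2ccc(F)cc2)nc(Br)c2cccnc12`: 7000 nM
- compound 3, `N[C@H]1CC[C@H](Nc2c(C(=O)NCc3ccccn3)nc(Br)c3cccnc23)CC1`: 4000 nM

All three share one core and are read in a functional assay on MDA-MB-435 cells (Homo sapiens) for cytotoxicity, read by MTT assay, with a stated time of 72 h; a higher number here means a weaker inhibitor, a lower number a stronger inhibitor. The value of compound 1 is a limit of the assay, not a number, as noted in the limit of > 10000 nM in this assay, at which 1 of the 3 values shown sits. Among the two numbers, compound 2 gives the higher one, but the gap to compound 3 lies within the scatter, so no order between compound 2 and compound 3 is claimed. For the measured compounds named here, the one measured step, an at least 2.5-fold lower number from compound 1 to compound 3 (0.39 log units; beyond the scatter), concerns the group on the amide side of the core.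

Compound 4, `O=C(NCc1ccc(F)cc1)c1nc(Br)c2cccnc2c1NCc1ccccc1`, is not yet measured. It differs from compound 2 by phenyl in place of 2-(dimethylamino)ethyl on a saturated chain carbon bound to a nitrogen on an aromatic ring, that is, benzylamino in place of (3-(dimethylamino)propyl)amino. Going by the values given here, no measured step touches this position; the only step known changes the amide side, so nothing in the data fixes the direction here. A step within the scatter in either direction is taken as the working assumption, with a real chance that only a limit is returned. In this assay compound 4 is expected at 6000 nM, with a range from 1500 nM to 20000 nM. That amounts to an expected 1.2-fold lower number from compound 2 to compound 4 (0.07 log units; within the scatter).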

Compound 4, half-maximal inhibitory concentration: > 20000 nM
Compound 4 was reported as a limit (the forecaster's own chance of this, stated with the estimate: 35%); at least 3.3-fold (0.52 log units) between middle value and limit.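

In this assay, the position on the saturated chain carbon bound to a nitrogen on an aromatic ring now has a measured step, whereas the earlier step concerned only the amide side: replacing 2-(dimethylamino)ethyl with phenyl gives an at least 2.8-fold higher number from compound 2 to compound 4 (0.45 log units; beyond the scatter). With the amide side held constant, this position therefore affects the read-out, and the direction of this one change runs toward a higher number, meaning a weaker inhibitor. The value of compound 4 is a limit of the assay and not a number: the limit of > 20000 nM in this assay, at which 1 of the 4 values shown sits.

The step removes the open chain with its dimethylamino group and brings in an aromatic ring at the same time, so the compounds shown cannot assign it to either part of the swap. Still open, going by these compounds, is whether a primary amine on the same propyl chain, a longer chain ending in dimethylamino, or a morpholine at the chain end would give a lower number than compound 2 at 7000 nM, and whether the amide-side step seen with the other amine group carries over to this chain.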